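One More Hydroxy Group: Expected Tolerance in Cells

This account rests on a few compounds, and the source may have more. Where it says the series, first, only, none or still open, it means among the compounds named here.

Of the compounds shown here, three sharing one core have been tested in an ADME assay on CCRF-CEM cells (Homo sapiens) for cytotoxicity; a lower number here means that less compound is tolerated, a higher number that more compound is tolerated. Compound 1 `C[C@@H](CO)NC(=O)c1cnc2ccccc2c1Cl` stops at the limit of the assay, > 100 uM, which is not a number. Compound 2 `COC(=O)CNC(=O)c1cnc2ccccc2c1Cl` likewise stops at the assay limit, > 100 uM. Among the compounds with values here, compound 3 `COC(=O)[C@H](C)NC(=O)c1cnc2ccccc2c1Cl` is the only one with a real number: in this assay compound 3 gives 81.3 uM. The steps that lead to it are small. There is an at least 1.2-fold lower number from compound 1 to compound 3 (0.08 log units; that floor lies within the scatter), and an at least 1.2-fold lower number from compound 2 to compound 3 (0.08 log units; that floor lies within the scatter), while a step that the two limits leave unreadable from compound 1 to compound 2.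

Compound 4 `COC(=O)[C@H](CO)NC(=O)c1cnc2ccccc2c1Cl` has not yet been measured. It differs from compound 3 by hydroxy in place of hydrogen on a saturated chain carbon, two bonds along the chain from an amide-type nitrogen and a carbonyl carbon. Within the data shown here, none of the measured steps adds a hydroxy group on its own, so the nearest guide is compound 1, which carries a hydroxymethyl group and reaches only the assay limit, > 100 uM. The step expected from compound 3 to compound 4 is therefore a 1.2-fold higher number from compound 3 to compound 4 (0.09 log units; within the scatter), nothing beyond the usual scatter. Compound 4 is estimated at 100 uM, between 50 uM and 200 uM, in this assay, with a fair chance that only a limit is reported again.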

Compound 4, half-maximal toxic concentration: > 100 uM
Compound 4 was reported as a limit (the forecaster's own chance of this, stated with the estimate: 50%); the middle value sits exactly at the limit.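

In this assay, within the data shown here, hydroxy in place of hydrogen on this saturated chain carbon can be read on its own for the first time, and it gives an at least 1.2-fold higher number from compound 3 to compound 4 (0.08 log units; that floor lies within the scatter). So with the methoxycarbonyl kept, hydroxymethyl can replace methyl here without any readable fall in the number, although no rise beyond the scatter is shown either. The steps to compound 4 from compound 1 and from compound 2 cannot be read, because both ends of each step are limits and not numbers: the limit of > 100 uM in this assay, at which 3 of the 4 values shown sit.

On these data alone, how far compound 1, compound 2 and compound 4 really lie past that limit stays open, and so does whether the hydroxy has any real effect on the number. Also open, as far as these compounds go, is what an amine in place of the hydroxy, a carboxylic acid in place of the methoxycarbonyl, or a longer chain on this carbon would do to the number.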